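Hydroxy for hydrogen on the phenyl of compound 2

A few compounds are considered here, and "the series" means these few. Any claim that something is new, unique, unknown or untested is made for them only; others in the source may bear on it.

Measured compounds:
compound 1 `N#Cc1c(-c2ccc(Cl)cc2)nc(SCC(=O)Nn2c(COc3ccc(Cl)cc3Cl)nc3ccccc3c2=O)n(Cc2ccccc2)c1=O` — 72.7%
compound 2 `N#Cc1c(Cl)nc(SCC(=O)Nn2c(COc3ccc(Cl)cc3Cl)nc3ccccc3c2=O)nc1-c1ccccc1` — 60%

Both compounds were tested in a functional assay on the whole organism (strain albino) for inhibition, with Rattus norvegicus as the target, read by paw edema, with a stated time of 1 h, at a dose of 100 mg/kg by the oral route; a lower number here means less inhibition, a higher number more inhibition at the dose given (going by the name of the read-out). Of the two numbers, compound 2 gives the lower value, 60%, and the nearest neighbour, compound 1, gives 72.7% and stands higher by a gap that lies beyond the scatter. Among the measured compounds shown here, no single-point step between measured compounds is available, so the size of a small change in this assay cannot be read from this pair.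

Compound 3 `N#Cc1c(Cl)nc(SCC(=O)Nn2c(COc3ccc(Cl)cc3Cl)nc3ccccc3c2=O)nc1-c1ccc(O)cc1` differs from compound 2 by hydroxy in place of hydrogen on an aromatic carbon. For the measured compounds named here, there is no measured precedent for this change. The step from compound 2 to compound 3 in this assay is expected to be small, in either direction, and probably not beyond the scatter: a number 2 percentage points higher from compound 2 to compound 3 (within the scatter). For compound 3 the expected value in this assay is 62%, with a range from 45% to 78%.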

Compound 3, a percentage reported as inhibition, in the whole organism at one dose (the size of the read-out at that dose, not a potency): 72.7%
Compound 3: middle estimate off by 10.7 percentage points, on the low side; low and high end bracket the measured number.
By their numbers in this assay, from the lowest: compound 2; then compounds 1 and 3 (each within the scatter of the next).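

In this assay, among the compounds shown here, the change from phenyl to 4-hydroxyphenyl gives the first single-place step: a number 12.7 percentage points higher from compound 2 to compound 3 (beyond the scatter). The carbon para to a large group on this ring is therefore a position where hydroxy in place of hydrogen, a change of one oxygen, raises inhibition at the dose given rather than lowering it. No available data bear on the reason for this step.

On these data alone, whether the rise is specific to hydroxy or would also appear with another group on this carbon remains open, and methoxy, an amine or a carboxylic acid there would help to separate those readings. Also open, as far as these compounds go, is whether the same hydroxy would give a comparable step on a different core, such as that of compound 1.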